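Removing the Sulfamoyl Group: What to Expect

The compounds below may be only part of what the source reports. "The series", "measured", "known", "first", "only" and "open" are said of these compounds alone.

Measured compounds:
Compound 1, `NS(=O)(=O)c1ccc(N2C(=O)CC(C3CCCCC3=O)C2=O)cc1`: 21300 nM
Compound 2, `NS(=O)(=O)c1ccc(N2C(=O)CC(C3CCCCCC3=O)C2=O)cc1`: 16200 nM

Of the compounds shown here, two have so far been measured in an assay on cells (1-87 tumor cell line) for inhibition of Polyunsaturated fatty acid 5-lipoxygenase (Homo sapiens), with a stated time of 5 min; on this read-out higher numbers stand for weaker inhibition and lower numbers for stronger inhibition. Compound 1 `NS(=O)(=O)c1ccc(N2C(=O)CC(C3CCCCC3=O)C2=O)cc1` gives 21300 nM, and compound 2 `NS(=O)(=O)c1ccc(N2C(=O)CC(C3CCCCCC3=O)C2=O)cc1` gives 16200 nM. Within the data shown here, the single step between them, a 1.3-fold lower number from compound 1 to compound 2 (0.12 log units; within the scatter), lies within the scatter, so the two numbers cannot be ordered against each other. Compound 2 thus holds the lower of the two numbers, but nothing sets it apart from compound 1.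

Compound 3 `O=C1CCCCCC1C1CC(=O)N(c2ccccc2)C1=O` has not yet been measured. It differs from compound 2 in one place: hydrogen in place of sulfamoyl on an aromatic carbon. Among the measured compounds shown here, no measured step bears on this change; the only step available concerned a different part of the molecule and stayed within the scatter. For the measured compounds named here, with no step to lean on, the expectation for compound 3 in this assay is a step of a 1.1-fold lower number from compound 2 to compound 3 (0.03 log units; within the scatter), that is, no change beyond the scatter, held with a wide range. Compound 3 is therefore estimated at 15000 nM, between 4000 nM and 50000 nM.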

Compound 3, half-maximal inhibitory concentration: 18400 nM
The estimate for compound 3 lay 1.2-fold (0.09 log units) below the measured number, within the range that was stated.
By their numbers in this assay, from the lowest: compounds 2, 3 and 1 (each within the scatter of the next).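

In this assay, hydrogen in place of sulfamoyl gives a 1.1-fold higher number from compound 2 to compound 3 (0.06 log units; within the scatter). Among these compounds, this is the first reading at this aromatic carbon, whereas the earlier step concerned only the 2-oxocycloheptyl and 2-oxocyclohexyl groups on the saturated ring carbon. In this pair, the whole sulfamoyl group, with its sulfur, nitrogen and two oxygen atoms, gives way to a hydrogen atom without the number leaving the scatter, so the inhibition seen with compound 2 does not depend on sulfamoyl being present, and no other information is available to explain this result.

The compounds shown leave open whether another group on this carbon, such as an amine, a carboxylic acid or a longer chain, would move the number beyond the scatter, since sulfamoyl and hydrogen are the only two groups compared here. They also leave open whether the same exchange would read alike with the 2-oxocyclohexyl group of compound 1 in place of the 2-oxocycloheptyl group, as this change has been followed only from compound 2.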